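A Methyl-for-Piperidinyl Swap Carried Across Two Cores

The source may report more compounds than this note shows. Statements on the series, on what has been measured and on what is new or still open speak of the compounds shown alone.

Compound 1 `CC(Nc1nc(N)nc2ccc(-c3cnn(C4CCNCC4)c3)cc12)c1c(Cl)ccc(F)c1Cl`: 2230 nM
Compound 2 `CC(Nc1ncnc2ncc(-c3cnn(C4CCNCC4)c3)cc12)c1c(Cl)ccc(F)c1Cl`: 1630 nM
Compound 3 `CC(Nc1nc(N)nc2ccc(-c3cnn(C)c3)cc12)c1c(Cl)ccc(F)c1Cl`: 2870 nM

Of the compounds shown here, three have been measured in a functional assay on MCF7 cells (Homo sapiens) for antiproliferative activity, read by MTT assay, with a stated time of 72 h; a lower number here means a stronger inhibitor, a higher number a weaker inhibitor. Compound 1 and compound 3 share one core; compound 2 carries another, and the difference between the two cores is not broken down here. The three values all fall within the scatter of one another, so no order among them can be read from these numbers.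

Compound 3 differs from compound 1 by methyl in place of piperidin-4-yl on an aromatic nitrogen. The resulting step, a 1.3-fold higher number from compound 1 to compound 3 (0.11 log units; within the scatter), is within the scatter. Compound 4 `CC(Nc1ncnc2ncc(-c3cnn(C)c3)cc12)c1c(Cl)ccc(F)c1Cl` has not yet been measured; it differs from compound 2 by methyl in place of piperidin-4-yl on an aromatic nitrogen, the same change made on the other core, at a place described in identical words.

Because the measured step of a 1.3-fold higher number from compound 1 to compound 3 (0.11 log units; within the scatter) lies within the scatter, a step of about the same size is expected here: a 1.3-fold higher number from compound 2 to compound 4 (0.11 log units; within the scatter). On that basis compound 4 is estimated at 2100 nM in this assay, with a likely range from 1000 nM to 4500 nM.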

Compound 4, half-maximal inhibitory concentration: > 100000 nM
Compound 4 gave a limit, no number; the forecaster's own chance of this, stated with the estimate: 5%; middle value at least 47-fold (1.67 log units) away from the limit.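

In this assay compound 4 stands at > 100000 nM, which is a limit of the assay and not a number. The change therefore gives an at least 61-fold higher number from compound 2 to compound 4 (1.78 log units; beyond the scatter), and a step measured on one core did not carry over to the other: the same change on two cores in this assay, a 1.3-fold higher number (0.11 log units; within the scatter) from compound 1 to compound 3 and an at least 61-fold higher number (1.78 log units; beyond the scatter) from compound 2 to compound 4, at least 47-fold (1.67 log units) apart, beyond the scatter of two such steps This shows that, for these two cores, the outcome of replacing piperidin-4-yl with methyl depends on the core, but it does not show which difference between the cores is responsible, how large the step on the core of compound 2 really is, or how the change would behave on any further core.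

The compounds shown leave open whether the ring of piperidin-4-yl or its nitrogen matters on the core of compound 2. A cyclohexyl group or a 2-aminoethyl chain on the same aromatic nitrogen could separate the two, showing whether such a compound stays with compound 2 or goes with compound 4.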